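The source may report more compounds than this note shows. Statements on the series, on what has been measured and on what is new or still open speak of the compounds shown alone.

Compound 1, `C=CC(=O)Nc1cc(Nc2ncc(Cl)c(Nc3ccccc3S(=O)(=O)C(C)C)n2)c(OC)cc1N1CCCN(C)CC1`: 15 nM
Compound 2, `C=CC(=O)Nc1cc(Nc2ncc(Cl)c(Nc3cccc(C(F)(F)F)c3)n2)c(OC)cc1N1CCN(C)CC1`: 260 nM

In a functional assay on NCI-H1975 cells (Homo sapiens) for inhibition, read by CellTiter-Glo, with a stated time of 72 h (on this read-out higher numbers stand for weaker inhibition of growth and lower numbers for stronger inhibition of growth), compound 1 gives 15 nM. In this assay, among the compounds with values here, compound 2 gives 260 nM, the higher of the two numbers measured so far; the gap between compound 2 and compound 1 lies beyond the scatter. Within the data shown here, compound 1 and compound 2 differ in more than one place, so no single step between them is counted, and nothing in the pair tells what any one change is worth.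

Compound 3, `C=CC(=O)Nc1cc(Nc2ncc(Cl)c(NCc3cccs3)n2)c(OC)cc1N1CCN(C)CC1`, has not yet been measured. It differs from compound 2 in one place: (thiophen-2-yl)methyl in place of 3-(trifluoromethyl)phenyl on a nitrogen on an aromatic ring. The same difference, cut one bond further out, reads (3-(trifluoromethyl)phenyl)amino to ((thiophen-2-yl)methyl)amino.

Among the measured compounds shown here, no counted step among the measured compounds bears on this change, so the expectation rests on the value of compound 2 alone and carries a wide range. In this assay the expected step is a 2.3-fold higher number from compound 2 to compound 3 (0.36 log units; beyond the scatter), a rise of moderate size that may or may not clear the scatter. Compound 3 is estimated at 600 nM, with a range from 150 nM to 3000 nM.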

Compound 3, concentration for 50% growth inhibition: 220 nM
Compound 3: the middle estimate sits 2.7-fold (0.44 log units) above what was measured; low and high end bracket the measured number.
By their numbers in this assay, from the lowest: compound 1; then compounds 3 and 2 (each within the scatter of the next).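

Within the data shown here, the first single-place step falls at this position: on the nitrogen on an aromatic ring, (thiophen-2-yl)methyl in place of 3-(trifluoromethyl)phenyl gives a 1.2-fold lower number from compound 2 to compound 3 (0.07 log units; within the scatter) in this assay. The position therefore accepts two quite different groups with no change in growth inhibition beyond the scatter, one a six-membered aromatic ring of carbon only with its trifluoromethyl group, the other a five-membered aromatic ring with a hetero atom, carried on a methyl link and with fewer heavy atoms. No measurement at hand accounts for this outcome.

Because the ring and the link change together in this one step, their separate contributions cannot be read from it, and a plain phenyl or a benzyl group on the same nitrogen would be needed to tell them apart. Also open, as far as these compounds go, are whether this tolerance extends to a non-aromatic group such as cyclohexylmethyl or a simple alkyl chain, and whether the same exchange would read alike on the core of compound 1.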